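Swapping the Sulfonyl Phenyl for Butyl: An Untested Step

A few compounds are considered here, and "the series" means these few. Any claim that something is new, unique, unknown or untested is made for them only; others in the source may bear on it.

compound 1 `CN1CCN(c2cccc3c2ccn3S(=O)(=O)c2ccccc2)CC1`: 1 nM
compound 2 `CC(=O)N1CCN(c2cccc3c2ccn3S(=O)(=O)c2ccccc2)CC1`: 714 nM
compound 3 `CN(C)c1cccc2c1ccn2S(=O)(=O)c1ccccc1`: 65 nM

In an assay on isolated protein for displacement of a labelled ligand from 5-hydroxytryptamine receptor 6 (Homo sapiens), read by scintillation counting, with a stated time of 1 h (a lower number here means a stronger inhibitor, a higher number a weaker inhibitor), compound 3 stands second highest of the three numbers, which follows from a 65-fold higher number from compound 1 to compound 3 (1.81 log units; beyond the scatter) and from an 11-fold lower number from compound 2 to compound 3 (1.04 log units; beyond the scatter). Compound 4 `CCCCS(=O)(=O)n1ccc2c(N(C)C)cccc21` has not yet been measured; it differs from compound 3 by butyl in place of phenyl on a sulfonyl sulfur. For the measured compounds named here, none of the measured steps touches this part of the molecule: a 710-fold higher number from compound 1 to compound 2 (2.85 log units; beyond the scatter), a 65-fold higher number from compound 1 to compound 3 (1.81 log units; beyond the scatter) and an 11-fold lower number from compound 2 to compound 3 (1.04 log units; beyond the scatter) all alter the amine side, so they give no guide to the sulfonyl substituent. The expectation therefore rests on the size of the change alone, and the estimated step is a 4.6-fold higher number from compound 3 to compound 4 (0.66 log units; beyond the scatter), with wide uncertainty. Compound 4 is expected to give 300 nM, within 40 nM to 2500 nM.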

Compound 4, inhibition constant: 49900 nM
Estimate against measurement, compound 4: 170-fold (2.22 log units) below; the whole stated range lies below it.
By their numbers in this assay, from the lowest: compound 1; then compound 3; then compound 2; then compound 4.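

In this assay the group on the sulfonyl sulfur matters a great deal: butyl in place of phenyl gives a 770-fold higher number from compound 3 to compound 4 (2.89 log units; beyond the scatter), a step comparable to the largest on the amine side, a 710-fold higher number from compound 1 to compound 2 (2.85 log units; beyond the scatter). So this part of the molecule can shift the number as strongly as the amine side can. No measurement here explains the size of this step.

Going by these compounds, whether the ring itself counts or any chain would behave this way remains open: benzyl, cyclohexyl or a shorter chain such as methyl on this sulfur could separate the two. Also open, on these data alone, is whether butyl has the same effect alongside 4-methylpiperazin-1-yl.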